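Shifting Two Methyl Groups Within an Inactive Series

The source may report more compounds than this note shows. Statements on the series, on what has been measured and on what is new or still open speak of the compounds shown alone.

Of the compounds shown here, three sharing one core have been measured in a functional assay on MGC-803 cells (Homo sapiens) for inhibition, read by MTT assay, with a stated time of 72 h; on this read-out higher numbers stand for weaker inhibition and lower numbers for stronger inhibition. Compound 1 `CC(C)n1ncc2c(C(=O)NC3CCCC3)cccc21` is the smallest of the three. In this assay compound 1 gives > 40000 nM, which is a limit of the assay rather than a number. Compound 2 `CC(C)n1ncc2c(C(=O)NCc3cn(-c4ccccc4)nn3)cccc21` carries a phenyl on an aromatic nitrogen, and compound 2 gives > 40000 nM, again a limit. Compound 3 `Cc1ccc(-n2cc(CNC(=O)c3cccc4c3cnn4C(C)C)nn2)cc1C` carries a 3,4-dimethylphenyl in place of that phenyl, and compound 3 gives > 40000 nM, also a limit. The change from phenyl to the dimethylphenyl therefore gives a step that the two limits leave unreadable from compound 2 to compound 3. Compound 3 thus stands with the other two at the limit of > 40000 nM in this assay, at which 3 of the 3 values shown sit.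

Compound 4 `Cc1ccc(-n2cc(CNC(=O)c3cccc4c3cnn4C(C)C)nn2)c(C)c1` differs from compound 3 by 2,4-dimethylphenyl in place of 3,4-dimethylphenyl on an aromatic nitrogen. Among the compounds with values here, the only measured step between compounds differing in one place could not be read, so nothing measured says how the placement of the two methyl groups matters. With all three compounds sitting at the limit, the expectation is that compound 4 also shows no measurable inhibition, an expected step that the limit leaves unreadable from compound 3 to compound 4. Compound 4 is therefore estimated at 50000 nM, with a range from 15000 nM to 150000 nM, most likely reported again only as a limit.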

Compound 4, half-maximal inhibitory concentration: > 40000 nM
Compound 4: only a limit was reported; the forecaster's own chance of this, stated with the estimate: 85%; the middle value is on the limit's open side.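

Compound 4 gives only a limit, as compound 2 and compound 3 do, so the steps from compound 3 and from compound 2 to compound 4 cannot be read: the limit of > 40000 nM in this assay, at which 4 of the 4 values shown sit. The compounds shown leave open whether swapping 3,4-dimethylphenyl for 2,4-dimethylphenyl changes inhibition at all, and what change to this series would bring a value inside the limit.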